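Five-membered heteroaryl variation on the shared core

The source may report more compounds than this note shows. Statements on the series, on what has been measured and on what is new or still open speak of the compounds shown alone.

Compound 3 `Cc1ccsc1-c1ccccc1NCC1=NCCN1` holds the highest of the two readable numbers in a functional assay for activation of Alpha-1B adrenergic receptor (Homo sapiens), read by calcium flux (on this read-out higher numbers stand for an effect only at larger amounts of compound and lower numbers for an effect already at smaller amounts), giving 112 nM. Its nearest neighbour is compound 2 `c1csc(-c2ccccc2NCC2=NCCN2)c1`, which in this assay gives 5.75 nM; between them lies a 19-fold higher number from compound 2 to compound 3 (1.29 log units; beyond the scatter). Compound 1 `Cc1ncc(-c2ccccc2NCC2=NCCN2)o1` gives only a limit in this assay, < 5020 nM. Because of the limit of < 5020 nM in this assay, at which 1 of the 3 values shown sits, the steps a step that the limit leaves unreadable from compound 1 to compound 2 and a step that the limit leaves unreadable from compound 1 to compound 3 cannot be sized.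

Compound 4 `Cc1ccc(-c2ccccc2NCC2=NCCN2)o1` is not yet measured. The change is 5-methylfuran-2-yl in place of 3-methylthiophen-2-yl on an aromatic carbon. Going by the values given here, no measured step covers this exchange directly: the only readable one, a 19-fold higher number from compound 2 to compound 3 (1.29 log units; beyond the scatter), concerns methyl against hydrogen on the thiophene ring alone, and the oxazole analogue, compound 1, gives no number to compare. That single step was large and upward in number, and compound 4 carries a methyl in a furan ring under a different name, so a partial return toward the number of compound 2 is taken as the working expectation, with wide uncertainty. Compound 4 is therefore expected to give about 30 nM in this assay, within 6 nM to 150 nM. The estimated step is a 3.7-fold lower number from compound 3 to compound 4 (0.57 log units; beyond the scatter), a lower number.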

Compound 4, half-maximal effective concentration: 46.8 nM
For compound 4 the middle estimate is 1.6-fold (0.19 log units) below the measured one; measured number inside the range.
By their numbers in this assay, from the lowest: compound 2; then compound 4; then compound 3.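

At this aromatic carbon, the methyl-bearing ring does not fix the number in this assay: 5-methylfuran-2-yl in place of 3-methylthiophen-2-yl gives a 2.4-fold lower number from compound 3 to compound 4 (0.38 log units; beyond the scatter). Against the ring without a methyl, 5-methylfuran-2-yl in place of thiophen-2-yl gives an 8.1-fold higher number from compound 2 to compound 4 (0.91 log units; beyond the scatter), so among the readable values both methyl-bearing rings sit on the higher side of compound 2, and the new group does not return to its number. Compound 1 gives only a limit, and the steps from it, including the one to compound 4, cannot be read: the limit of < 5020 nM in this assay, at which 1 of the 4 values shown sits.

The exchange from compound 3 to compound 4 alters both the ring hetero atom, sulfur to oxygen, and the name-given place of the methyl, so the compounds shown cannot assign the step to either change alone. Furan-2-yl without a methyl and 5-methylthiophen-2-yl would part these two changes, and how an aminomethyl group or a carboxylic acid on the five-membered ring would read in this assay remains open.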